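Compound 3 to Compound 4: An Expected Intrinsic Activity

A few compounds are considered here, and "the series" means these few. Any claim that something is new, unique, unknown or untested is made for them only; others in the source may bear on it.

Of the compounds shown here, three have been measured in a functional assay for agonist activity at growth hormone secretagogue receptor type 1 (Homo sapiens), read by FLIPR; a lower number here means a smaller maximal response, a higher number a larger maximal response. Among the compounds with values here, compound 1 `CCOc1ccc(N2C[C@@H](C)N[C@@H](C)C2)cc1NS(=O)(=O)c1ccc(-c2ccccn2)s1` gives 0.8 and compound 2 `C[C@@H]1CN(c2ccc(Cl)c(NS(=O)(=O)c3ccc(-c4ccccn4)s3)c2)C[C@H](C)N1` gives 1; the step a number 0.20 higher from compound 1 to compound 2 (beyond the scatter) is the only measured step between compounds that differ in one place. Compound 3 `COc1ccc(F)c(-c2ccc(S(=O)(=O)Nc3cc(N4C[C@@H](C)N[C@@H](C)C4)ccc3OC)cc2)c1` gives 1.2, the highest of the three numbers, standing beyond the scatter above both compound 2 and compound 1.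

Compound 4 `COc1ccc(N2C[C@@H](C)N[C@@H](C)C2)cc1NS(=O)(=O)c1ccc(N2CCCC2=O)cc1` differs from compound 3 by a single change, (2-oxopyrrolidin-1-yl in place of 2-fluoro-5-methoxyphenyl on an aromatic carbon). Within the data shown here, the one measured step concerns a different aromatic ring, so no measured step bears directly on this change, and the direction it takes is open. All three measured values fall in a narrow band around the reference response, so compound 4 is expected to stay near that band rather than move far from it. Compound 4 is estimated at 0.9, within a range from 0.6 to 1.2. That estimate means an expected step of a number 0.30 lower from compound 3 to compound 4 (beyond the scatter), a modest downward move that is anticipated, not measured.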

Compound 4, intrinsic activity: the largest response reached, as a fraction of the reference agonist's: 0.8
Beside the measured number, compound 4's estimate is 0.10 above it; the measured number falls inside the stated range.
By their numbers in this assay, from the lowest: compounds 1 and 4 (each within the scatter of the next); then compound 2; then compound 3.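

In this assay, replacing 2-fluoro-5-methoxyphenyl with 2-oxopyrrolidin-1-yl on this aromatic carbon, para to a large group, gives a large step, a number 0.40 lower from compound 3 to compound 4 (beyond the scatter), so the group held here bears on the maximal response. Within the data shown here, the earlier compounds could not show this, as their one measured step concerned a different aromatic ring. The exchange alters several things at once, removing a six-membered aromatic ring and bringing in a five-membered non-aromatic ring with a double bond outside it, and nothing available explains the drop in response.

Which of these differences carries the step remains open. Also open, as far as these compounds go, is whether a plain phenyl or a morpholine on the same carbon would stay with the larger response of compound 3 or the smaller response of compound 4.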